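This account rests on a few compounds, and the source may have more. Where it says the series, first, only, none or still open, it means among the compounds named here.

Of the compounds shown here, three with a shared amide core have been measured in a functional assay on HL-60 cells (Homo sapiens) for cytotoxicity, read by luminescence and CellTiter-Glo, with a stated time of 3 days; on this read-out higher numbers stand for weaker inhibition and lower numbers for stronger inhibition. Compound 1 `O=C(Nc1ccc(OC(F)(F)F)c(Cl)c1)c1ccc(C(F)(F)F)cc1O` gives 380 nM in this assay, and compound 2 `O=C(Nc1ccc(C(F)(F)F)cc1)c1cc(Cl)c(-c2ccccc2)cc1O` gives 490 nM. Compound 3 `N#Cc1ccc(NC(=O)c2ccc(-c3cccnc3)cc2O)cc1` gives 6660 nM in this assay, the highest of the three numbers; both compound 2 and compound 1 lie below it by margins beyond the usual scatter, so compound 3 is the weakest inhibitor of the set.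

The step under consideration leads to compound 4 `N#Cc1ccc(NC(=O)c2ccc(-c3ccccc3)cc2O)cc1`. The change is phenyl in place of pyridin-3-yl on an aromatic carbon, placed on an aromatic carbon of a six-membered aromatic ring of carbon only, meta to a hydroxy group and para to a large group. Compound 2, which also carries a phenyl on its core, sits well below compound 3, although its anilide part differs as well, so no clean comparison exists. A moderate downward step, toward stronger inhibition, is expected for compound 4, as a 2.7-fold lower number from compound 3 to compound 4 (0.43 log units; beyond the scatter), with compound 4 estimated at 2500 nM, within a range from 900 nM to 7000 nM.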

Compound 4, half-maximal inhibitory concentration: 700 nM
The estimate for compound 4 lay 3.6-fold (0.55 log units) above the measured number; measured number outside the range, below it.
By their numbers in this assay, from the lowest: compounds 1, 2 and 4 (each within the scatter of the next); then compound 3.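

In this assay, among these compounds, the exchange of pyridin-3-yl for phenyl, on an aromatic carbon meta to a hydroxy group and para to a large group, gives a 9.5-fold lower number from compound 3 to compound 4 (0.98 log units; beyond the scatter) and is the first comparison in this set in which only one place changes. It shows that this position responds to a change within the ring itself: both groups are six-membered aromatic rings of 6 heavy atoms, and they differ only in one ring nitrogen replaced by carbon, with one hydrogen-bond acceptor fewer by count. Nothing given here explains why the number moves at this position.

On these data alone, whether pyridin-4-yl, with its ring nitrogen elsewhere, would behave like pyridin-3-yl remains open. So does the effect of an amine or a carboxylic acid on the phenyl at this place.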